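Naphthalen-1-yl in Place of 3,4-Dichlorophenyl in Compound 4

The source may hold more compounds than are shown below. What is called first, only, known or untested is meant among the compounds shown, and "the series" means these compounds.

In a functional assay on GBM1 cells (Homo sapiens) for antiproliferative activity, read by WST assay, with a stated time of 72 h (a lower number here means a stronger inhibitor, a higher number a weaker inhibitor), compound 3 (`O=C(Nc1ccc(Cl)c(Cl)c1)Nc1cc2ncncc2cc1OCc1cccc(F)c1`) gives 2100 nM. Compound 1 (`O=C(Nc1ccc(C(F)(F)F)cc1)Nc1cc2ncncc2cc1OCc1cccc(F)c1`) gives 3800 nM, and the measured step, a 1.8-fold lower number from compound 1 to compound 3 (0.26 log units; within the scatter), does not separate the two. Compound 2 (`O=C(Nc1cc2ncncc2cc1OCc1ccc(F)cc1)Nc1cccc2ccccc12`) gives 8100 nM, a gap from compound 3 that lies beyond the scatter.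

Compound 4 (`O=C(Nc1cc2ncncc2cc1OCc1cccc(F)c1)Nc1cccc2ccccc12`) carries naphthalen-1-yl in place of 3,4-dichlorophenyl on an amide-type nitrogen. Among the compounds with values here, the only measured step at this place is the one already given, which replaced 4-(trifluoromethyl)phenyl and stayed small, so it offers limited guidance. The closer reference is compound 2 at 8100 nM, which also bears naphthalen-1-yl but differs from compound 4 elsewhere in the molecule. Within the data shown here, no measured step isolates that remaining difference, so the reference is imperfect. A higher number is therefore expected, with an estimated step of a 2.6-fold higher number from compound 3 to compound 4 (0.42 log units; beyond the scatter). The estimate for compound 4 is 5500 nM, with an expected range of 2200 nM to 13000 nM.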

Compound 4, half-maximal inhibitory concentration: 1300 nM
Compound 4: middle estimate off by 4.2-fold (0.63 log units), on the high side; the measured number lies below the stated range.
By their numbers in this assay, from the lowest: compounds 4, 3 and 1 (each within the scatter of the next, the first and the last beyond it); then compound 2.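

In this assay, naphthalen-1-yl on the amide-type nitrogen does not separate from 3,4-dichlorophenyl (a 1.6-fold lower number from compound 3 to compound 4 (0.21 log units; within the scatter)), yet it does separate from 4-(trifluoromethyl)phenyl (a 2.9-fold lower number from compound 1 to compound 4 (0.47 log units; beyond the scatter)), even though compound 1 and compound 3 lie within the scatter of each other. The high number of compound 2 therefore cannot be read as a property of naphthalen-1-yl alone: with that group held constant, 3-fluorophenyl in place of 4-fluorophenyl on the saturated chain carbon gives the largest step here (a 6.2-fold lower number from compound 2 to compound 4 (0.79 log units; beyond the scatter)). No evidence is available to explain either step.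

Going by these compounds, it remains open whether a group carrying an amine or a carboxylic acid on the amide-type nitrogen would stay in this range. Also open, on these data alone, is whether the 3-fluorophenyl over 4-fluorophenyl step holds with 3,4-dichlorophenyl on that nitrogen.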